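The source may hold more compounds than are shown below. What is called first, only, known or untested is meant among the compounds shown, and "the series" means these compounds.

Working notes on the nitrooxy ester set. Compound 1 `O=C(/C=C/c1ccc(OCCCCCO[N+](=O)[O-])c(O)c1)OCCCCCO[N+](=O)[O-]` and compound 3 `O=C(/C=C/c1ccc(OCCCCO[N+](=O)[O-])c(O)c1)OCCCCO[N+](=O)[O-]` each carry two nitrooxy-bearing chains; compound 2 `COc1cc(/C=C/C(=O)OC/C=C/CO[N+](=O)[O-])ccc1O` carries a single one. In a functional assay on NCI-H1299 cells (Homo sapiens) for cytotoxicity, read by resazurin assay, with a stated time of 72 h (a higher number here means a weaker inhibitor, a lower number a stronger inhibitor), compound 1 gives only a limit, > 50000 nM. Compound 3 likewise gives only a limit in this assay, > 50000 nM. Among the compounds with values here, compound 2 gives a number in this assay, 2340 nM, and so stands as the only measured value in the set; the remainder is the limit of > 50000 nM in this assay, at which 2 of the 3 values shown sit. Compound 4 `COc1cc(/C=C/C(=O)OCCCO[N+](=O)[O-])ccc1O` is drawn from compound 2 by a group of 6 heavy atoms (2 carbon, 1 nitrogen, 3 oxygen; no ring) in place of a group of 7 heavy atoms (3 carbon, 1 nitrogen, 3 oxygen; no ring), on a saturated chain carbon bound to an oxygen next to a carbonyl group. Within the data shown here, no step between two measured compounds covers a change of this kind, so the expectation rests on the change alone: the core of compound 2 is kept, a group of 6 heavy atoms replaces a group of 7 on a saturated chain carbon bound to an oxygen next to a carbonyl group, and 2 double bonds outside aromatic rings give way to 1. The expected step of a 1.5-fold higher number from compound 2 to compound 4 (0.17 log units; within the scatter) is therefore small, a mild weakening at most, hardly beyond the scatter. Compound 4 is expected to give about 3500 nM in this assay, within a range from 1200 nM to 11000 nM.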

Compound 4, half-maximal inhibitory concentration: 28300 nM
For compound 4 the middle estimate is 8.1-fold (0.91 log units) below the measured one, and the stated range ends below it.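

In this assay, within the data shown here, the exchange for 2-(nitrooxy)ethyl on a saturated chain carbon bound to an oxygen next to a carbonyl group gives a 12-fold higher number from compound 2 to compound 4 (1.08 log units; beyond the scatter), the first step in the set that can be read at this place, and it shows that this place is sensitive to a small change in the chain. The hydrogen-bond donor and acceptor counts are the same in the leaving and entering groups, so the step goes with the change in carbon count and the loss of a double bond outside aromatic rings, not with those counts. Nothing measured here bears on the cause of the step.

Carbon count and double bond change together in this single pair, and the compounds shown do not separate them. A longer saturated chain ending in the nitrooxy group, or an amine or a carboxylic acid in its place, lies outside the compounds shown.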